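This account rests on a few compounds, and the source may have more. Where it says the series, first, only, none or still open, it means among the compounds named here.

Measured in a functional assay on A549 cells (Homo sapiens) for cytotoxicity, with a stated time of 48 h; on this read-out higher numbers stand for weaker inhibition and lower numbers for stronger inhibition:
compound 1 `C[S+]([O-])/C=C/c1cc(=O)c2cc(C#N)ccc2o1`: > 10000 nM, a limit of the assay rather than a number
compound 2 `C[S+]([O-])/C=C/c1cc(=O)c2cc(F)ccc2o1`: 2100 nM
compound 3 `CCCC(=O)Oc1ccc2oc(/C=C/[S+](C)[O-])cc(=O)c2c1`: 2200 nM

Compound 3 sits at the highest of the two numbers shown, with compound 2 nearest at a 1.0-fold higher number from compound 2 to compound 3 (0.02 log units; within the scatter). Compound 4 `COc1ccc2oc(/C=C/[S+](C)[O-])cc(=O)c2c1` is not yet measured; it differs from compound 3 by methyl in place of propylcarbonyl on an oxygen on an aromatic ring. Within the data shown here, no measured step changes a group on this oxygen. The steps at the same aromatic carbon are an at least 4.7-fold lower number from compound 1 to compound 2 (0.67 log units; beyond the scatter) and an at least 4.5-fold lower number from compound 1 to compound 3 (0.65 log units; beyond the scatter), both starting from the limit (the limit of > 10000 nM in this assay, at which 1 of the 3 values shown sits), and a 1.0-fold higher number from compound 2 to compound 3 (0.02 log units; within the scatter), so fluoro and (propylcarbonyl)oxy gave numbers that cannot be told apart. A step within the scatter is therefore expected in this assay for compound 4, namely a 1.1-fold higher number from compound 3 to compound 4 (0.06 log units; within the scatter). Compound 4 is estimated at 2500 nM, in a range from 900 nM to 7000 nM.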

Compound 4, half-maximal inhibitory concentration: 1600 nM
Compound 4: the middle estimate sits 1.6-fold (0.19 log units) above what was measured, and the stated range covers the measured number.
By their numbers in this assay, from the lowest: compounds 4, 2 and 3 (each within the scatter of the next). At a limit, above all of these: compound 1.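

In this assay, methyl in place of propylcarbonyl on this oxygen gives a 1.4-fold lower number from compound 3 to compound 4 (0.14 log units; within the scatter), so the size of this group makes no readable difference here. Methoxy against fluoro on the aromatic carbon gives a 1.3-fold lower number from compound 2 to compound 4 (0.12 log units; within the scatter), which puts methoxy, fluoro and (propylcarbonyl)oxy together within the scatter. Only cyano stands apart, with an at least 6.2-fold lower number from compound 1 to compound 4 (0.79 log units; beyond the scatter), and compound 1 is a limit rather than a number: the limit of > 10000 nM in this assay, at which 1 of the 4 values shown sits.

From the compounds shown here alone, whether a free hydroxyl, an amine or a carboxylic acid at this aromatic carbon would stay with these numbers remains open. So does whether a longer chain on this oxygen would.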